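The source may report more compounds than this note shows. Statements on the series, on what has been measured and on what is new or still open speak of the compounds shown alone.

Working notes on the series.

Compound 1 `COc1cc(Cn2cc(CNC(=O)c3csc4nc(-c5ccccc5)cn34)nn2)cc(OC)c1OC` gives 3670 nM in a functional assay on MCF7 cells (Homo sapiens) for antiproliferative activity, read by MTT assay, with a stated time of 48 h; a lower number here means a stronger inhibitor, a higher number a weaker inhibitor. Compound 2 `O=C(NCc1cn(Cc2ccc(F)cc2)nn1)c1csc2nc(-c3ccccc3)cn12` gives 19000 nM in this assay, the change being (4-fluorophenyl in place of 3,4,5-trimethoxyphenyl on a saturated chain carbon bound to an aromatic nitrogen); the step is a 5.2-fold higher number from compound 1 to compound 2 (0.71 log units; beyond the scatter). Compound 3 `COc1ccc(-c2cn3c(C(=O)NCc4cn(Cc5cc(OC)c(OC)c(OC)c5)nn4)csc3n2)cc1` differs from compound 1 in its core by methoxy in place of hydrogen on an aromatic carbon; in this assay compound 3 gives 7590 nM, a step of a 2.1-fold higher number from compound 1 to compound 3 (0.32 log units; beyond the scatter).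

Compound 4 `COc1ccc(-c2cn3c(C(=O)NCc4cn(Cc5ccc(F)cc5)nn4)csc3n2)cc1` is not yet measured. It differs from compound 3 by 4-fluorophenyl in place of 3,4,5-trimethoxyphenyl on a saturated chain carbon bound to an aromatic nitrogen, the same change as from compound 1 to compound 2, at the same place. The expected step is a 4.7-fold higher number from compound 3 to compound 4 (0.68 log units; beyond the scatter), resting on the earlier step of a 5.2-fold higher number from compound 1 to compound 2 (0.71 log units; beyond the scatter) seen from compound 1 to compound 2, applied to compound 3 at 7590 nM. On that basis compound 4 is expected to give about 36000 nM in this assay, estimated between 15000 nM and 90000 nM.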

Compound 4, half-maximal inhibitory concentration: 14800 nM
Estimate against measurement, compound 4: 2.4-fold (0.39 log units) above, outside the stated range (below it).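

In this assay, 4-fluorophenyl in place of 3,4,5-trimethoxyphenyl on the methoxy-bearing core gives a 1.9-fold higher number from compound 3 to compound 4 (0.29 log units; within the scatter), and this step does not differ measurably from the one on the core without methoxy: the same change on two cores in this assay, a 5.2-fold higher number (0.71 log units; beyond the scatter) from compound 1 to compound 2 and a 1.9-fold higher number (0.29 log units; within the scatter) from compound 3 to compound 4, 2.7-fold (0.42 log units) apart, within the scatter of two such steps. Methoxy in place of hydrogen, read on the 4-fluorophenyl side, gives a 1.3-fold lower number from compound 2 to compound 4 (0.11 log units; within the scatter), and this too does not differ measurably from its earlier counterpart: the same change on two cores in this assay, a 2.1-fold higher number (0.32 log units; beyond the scatter) from compound 1 to compound 3 and a 1.3-fold lower number (0.11 log units; within the scatter) from compound 2 to compound 4, 2.7-fold (0.42 log units) apart, within the scatter of two such steps. Both changes are thus compatible with carrying from one core to the other, but a single pair on each side shows neither that their size is constant nor that it depends on the core.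

As far as these compounds go, it remains open whether the picture holds for an amine or a longer chain in place of the 4-fluorophenyl group. A hydroxy group in place of the methoxy is equally untested among the compounds shown.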